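Fluoro for Hydrogen, Repeated on a Second Core

The source may hold more compounds than are shown below. What is called first, only, known or untested is meant among the compounds shown, and "the series" means these compounds.

Compound 1 `Cc1cc(=O)n(-c2ccc(Br)cc2F)nc1C(=O)Nc1ccc(Oc2ncnc3ccsc23)cc1`: 10600 nM
Compound 2 `Cc1cc(=O)n(-c2ccc(Br)cc2F)nc1C(=O)Nc1ccc(Oc2ncnc3ccsc23)c(F)c1`: 3350 nM
Compound 3 `Cc1cc(=O)n(-c2ccc(F)cc2)nc1C(=O)Nc1ccc(Oc2ncnc3sccc23)c(F)c1`: 12500 nM

In a functional assay on HepG2 cells (Homo sapiens) for cytotoxicity, read by MTT assay, with a stated time of 72 h (a higher number here means a weaker inhibitor, a lower number a stronger inhibitor), compound 1 gives 10600 nM and compound 2 gives 3350 nM. The change between them is fluoro in place of hydrogen on an aromatic carbon; it produced a 3.2-fold lower number from compound 1 to compound 2 (0.50 log units; beyond the scatter). Compound 3 gives 12500 nM in this assay; the difference between its core and the core of compound 1 is not broken down here. Compound 4 `Cc1cc(=O)n(-c2ccc(F)c(F)c2)nc1C(=O)Nc1ccc(Oc2ncnc3sccc23)c(F)c1` is not yet measured; it differs from compound 3 by fluoro in place of hydrogen on an aromatic carbon. Among the measured compounds shown here, this is the same kind of change as the one from compound 1 to compound 2, but the place differs: there the entering fluoro sat ortho to a large group, here it sits ortho to a fluoro group. Resting on the earlier step of a 3.2-fold lower number from compound 1 to compound 2 (0.50 log units; beyond the scatter), compound 4 is expected to show a 2.1-fold lower number from compound 3 to compound 4 (0.32 log units; beyond the scatter) in this assay. Compound 4 is estimated at 6000 nM, between 2500 nM and 15000 nM.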

Compound 4, half-maximal inhibitory concentration: > 40000 nM
Compound 4: no number, only a limit; the forecaster's own chance of this, stated with the estimate: 10%; at least 6.6-fold (0.82 log units) between middle value and limit.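

On the second core the change gave an at least 3.2-fold higher number from compound 3 to compound 4 (0.50 log units; beyond the scatter) in this assay, so the earlier result did not carry over from the core of compound 1 to the core of compound 3: the same change on two cores in this assay, a 3.2-fold lower number (0.50 log units; beyond the scatter) from compound 1 to compound 2 and an at least 3.2-fold higher number (0.50 log units; beyond the scatter) from compound 3 to compound 4, at least 10-fold (1.00 log units) apart, beyond the scatter of two such steps

From the compounds shown here alone, for compound 4, > 40000 nM is a limit of the assay and not a number, so the full size of this step stays unknown. With one pair on each core, and with the two pairs differing both in the core and in the place of the entering fluoro, the result does not show which of these decides the direction of the step.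

The compounds shown leave open how a chloro or a methoxy group at the place of the entering fluoro in compound 4 would read in this assay.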